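Chloro for methoxy on a fused ring core

The compounds below may be only part of what the source reports. "The series", "measured", "known", "first", "only" and "open" are said of these compounds alone.

Compound 1 `COc1cc(C)nc2n/c(=N/C(=O)c3c(-c4ccc(Cl)cc4Cl)noc3C)sn12`: 30.9%
Compound 2 `Cc1onc(-c2ccc(Cl)cc2Cl)c1C(=O)/N=c1/nc2nc(Cl)cc(C)n2s1`: 25.8%
Compound 3 `COc1cc(OC)n2s/c(=N\C(=O)c3c(-c4ccc(Cl)cc4Cl)noc3C)nc2n1`: 43.2%

Of the compounds shown here, three share one core and have been tested in a functional assay on the whole organism (strain L.) for inhibition, with Echinochloa crus-galli as the target, with a stated time of 72 h, tested at 10 mg/L; a higher number here means more inhibition of growth at the concentration tested, a lower number less inhibition of growth. Compound 3 has the highest number of the three: the step of a number 12.3 percentage points higher from compound 1 to compound 3 (beyond the scatter) lies beyond the scatter, and compound 3 also stands above compound 2 by a gap beyond the scatter. Compound 1 and compound 2 differ from one another by chloro in place of methoxy, and their two numbers lie within the scatter of each other, so nothing can be said about their order.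

Compound 4 `COc1cc(Cl)nc2n/c(=N/C(=O)c3c(-c4ccc(Cl)cc4Cl)noc3C)sn12` has not yet been measured. It differs from compound 3 in one place: chloro in place of methoxy on an aromatic carbon. For the measured compounds named here, no measured step is available for exactly this change. Going by the values given here, the only measured step, from compound 1 to compound 3, concerns methoxy replacing methyl and so does not bear on it directly; the pair compound 1 and compound 2 shows the same kind of swap, and their values differ only within the scatter. The expected step of a number 8.2 percentage points lower from compound 3 to compound 4 (within the scatter) is therefore small, possibly a slight drop, and may lie within the scatter. For compound 4 the estimated value in this assay is 35%, with an expected range from 20% to 50%.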

Compound 4, percent growth inhibition at one concentration: 10.8%
Estimate against measurement, compound 4: 24.2 percentage points above; the measured number lies below the stated range.
By their numbers in this assay, from the lowest: compound 4; then compounds 2 and 1 (each within the scatter of the next); then compound 3.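

Chloro in place of methoxy on this aromatic carbon brings a number 32.4 percentage points lower from compound 3 to compound 4 (beyond the scatter) in this assay, although compound 1 at 30.9% and compound 2 at 25.8%, which differ by the same kind of swap, lie within the scatter of each other. Chloro also compares poorly with methyl on the core that keeps one methoxy group, giving a number 20.1 percentage points lower from compound 1 to compound 4 (beyond the scatter). The result further shows that methoxy in place of methyl has no single direction in these compounds, and that the outcome of a swap depends on the group that stays on the ring, with a number 15 percentage points lower from compound 2 to compound 4 (beyond the scatter) set against the earlier rise: the same change on two cores in this assay, a number 12.3 percentage points higher (beyond the scatter) from compound 1 to compound 3 and a number 15 percentage points lower (beyond the scatter) from compound 2 to compound 4, 27.3 percentage points apart, beyond the scatter of two such steps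

These four compounds give the size and direction of these swaps but not the reason why one group's effect depends on its partner, and each result rests on a single concentration. As far as these compounds go, it also remains open whether an amine or an ethoxy group on this aromatic carbon would track methoxy or chloro, and whether the same dependence would hold with either group paired with it.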